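The source may report more compounds than this note shows. Statements on the series, on what has been measured and on what is new or still open speak of the compounds shown alone.

Measured so far in an assay on isolated protein for inhibition of ATP-citrate synthase (Rattus norvegicus); a higher number here means a weaker inhibitor, a lower number a stronger inhibitor:
compound 1, `O=C(O)CC(O)(CSCCc1ccc(Cl)cc1Cl)C(=O)O`, gives 480000 nM
compound 2, `O=C(O)CC(O)(CSCCCc1ccc(Cl)cc1Cl)C(=O)O`, gives 390000 nM
compound 3, `O=C(O)CC(O)(CSCCCCCCc1ccc(Cl)cc1Cl)C(=O)O`, gives 3300 nM

Compound 3 stands lowest of the three numbers in this assay. Its nearest neighbour is compound 2, whose number is higher by a gap beyond the scatter; compound 1 lies higher still. The three share one core and differ only in the saturated chain that carries the 2,4-dichlorophenyl group, and only compound 3 reaches the low value.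

Compound 4, `COc1ccc(CCCCCCSCC(O)(CC(=O)O)C(=O)O)cc1`, keeps the saturated chain of compound 3. The change is 4-methoxyphenyl in place of 2,4-dichlorophenyl on a saturated chain carbon, six bonds along the chain from a sulfur. For the measured compounds named here, no measured pair shows this exchange, so the size of the step rests on no data from this assay. The expectation for compound 4 is a moderate rise in the number, beyond the scatter, estimated as a 3.0-fold higher number from compound 3 to compound 4 (0.48 log units; beyond the scatter). Compound 4 is accordingly expected to give about 10000 nM, with a plausible range from 3000 nM to 50000 nM.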

Compound 4, inhibition constant: 280000 nM
The estimate for compound 4 lay 28-fold (1.45 log units) below the measured number; measured number above the stated range.
By their numbers in this assay, from the lowest: compound 3; then compounds 4, 2 and 1 (each within the scatter of the next).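

In this assay, 4-methoxyphenyl in place of 2,4-dichlorophenyl on a saturated chain carbon, six bonds along the chain from a sulfur, gives an 85-fold higher number from compound 3 to compound 4 (1.93 log units; beyond the scatter). The earlier compounds shown here all carry 2,4-dichlorophenyl and vary only in the chain, so they could not show that the aryl group matters here as well: the saturated chain of compound 3 does not by itself secure the low number. Nothing at hand accounts for the size of this step.

The compounds shown do not separate the loss of the two chlorines from the arrival of the methoxy group, a question that a plain phenyl group on the same chain would address. From the compounds shown here alone, whether a longer chain would lower the number further also remains open.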